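The compounds below may be only part of what the source reports. "The series", "measured", "known", "first", "only" and "open" are said of these compounds alone.

Measured so far in a toxicity assay on KB cells (Homo sapiens) for cytotoxicity, read by fluorescence, with a stated time of 3 days; a lower number here means that less compound is needed, a higher number that more compound is needed for the effect:
compound 1, `CCCCOC(=O)CNC(=O)[C@H](CSc1ccc([N+](=O)[O-])cc1[N+](=O)[O-])NC(=O)CC[C@H](N)C(=O)OCCCC`: 107 uM
compound 2, `CCCCOC(=O)CNC(=O)[C@H](CSc1ccc([N+](=O)[O-])cc1[N+](=O)[O-])NC(=O)CC[C@H](NC(=O)OC)C(=O)OCCCC`: > 300 uM

Compound 1 carries a free amine. Compound 2 carries methoxycarbonyl on that nitrogen, and in this assay compound 2 gives only a limit, > 300 uM. Among the compounds with values here, the one step measured so far, an at least 2.8-fold higher number from compound 1 to compound 2 (0.44 log units; beyond the scatter), is therefore known only as a lower bound, set by the limit of > 300 uM in this assay, at which 1 of the 2 values shown sits; compound 2 stands at the high end of everything measured here.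

Compound 3, `CCCCOC(=O)CNC(=O)[C@H](CSc1ccc([N+](=O)[O-])cc1[N+](=O)[O-])NC(=O)CC[C@H](Nc1nc(N)nc(Cl)n1)C(=O)OCCCC`, differs from compound 2 by 4-amino-6-chloro-1,3,5-triazin-2-yl in place of methoxycarbonyl on an amine nitrogen. The entering group is larger than the leaving one and brings one hydrogen-bond donor and four acceptors, where methoxycarbonyl brought none and two. Within the data shown here, only the step from compound 1 to compound 2 bears on this change, and it speaks to the nitrogen being substituted at all rather than to which group sits on it. Since the nitrogen stays substituted in compound 3, no step beyond the scatter is expected from compound 2, and compound 3 is expected to land near the limit again, with the step of an at least 1.2-fold lower number from compound 2 to compound 3 (0.07 log units; that floor lies within the scatter) reflecting no more than that. Compound 3 is thus estimated at 250 uM, within 80 uM to 500 uM.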

Compound 3, concentration for half-maximal effect: > 300 uM
Compound 3: only a limit was reported; the forecaster's own chance of this, stated with the estimate: 55%; middle value at least 1.2-fold (0.07 log units) away from the limit.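

In this assay compound 3 gives > 300 uM, which is a limit of the assay and not a number. Placing 4-amino-6-chloro-1,3,5-triazin-2-yl on the amine nitrogen gives an at least 2.8-fold higher number from compound 1 to compound 3 (0.44 log units; beyond the scatter), so a second substituent, quite different in its counted atoms and ring from methoxycarbonyl, also moves the read-out beyond the scatter relative to the free amine of compound 1. The step between compound 2 and compound 3 cannot be read, and any difference between the two substituents on this nitrogen stays hidden: the limit of > 300 uM in this assay, at which 2 of the 3 values shown sit.

The compounds shown therefore do not rank methoxycarbonyl against 4-amino-6-chloro-1,3,5-triazin-2-yl, and they do not tell how far the true values of compound 2 and compound 3 lie from the free amine of compound 1. They also leave open whether a simple methyl or acetyl group on this nitrogen would behave in the same way, and whether a carboxylic acid in place of either butyl ester would alter the picture.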